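The source may report more compounds than this note shows. Statements on the series, on what has been measured and on what is new or still open speak of the compounds shown alone.

Measured in a functional assay on HeLa cells (Homo sapiens) for inhibition, read by CCK-8 assay, with a stated time of 72 h; on this read-out higher numbers stand for weaker inhibition and lower numbers for stronger inhibition:
- Compound 1 `Cc1ccc(NS(=O)(=O)c2cccc(CCCCCCNC(=O)/C=C/c3cccnc3)c2)cc1`: 38.8 nM
- Compound 2 `Cc1ccccc1NS(=O)(=O)c1cccc(CCCCCCNC(=O)/C=C/c2cccnc2)c1`: 2.34 nM

Of these two, compound 2 has the lower number in this assay, and the gap to compound 1 lies beyond the scatter. Compound 3 `Cc1ccc(C)c(NS(=O)(=O)c2cccc(CCCCCCNC(=O)/C=C/c3cccnc3)c2)c1` keeps the 2-methylphenyl group and turns it into 2,5-dimethylphenyl: methyl in place of hydrogen on an aromatic carbon. For the measured compounds named here, one measured step bears on this, and only indirectly. It is a 17-fold lower number from compound 1 to compound 2 (1.22 log units; beyond the scatter), a large step, with 2-methylphenyl in place of 4-methylphenyl on a sulfonamide nitrogen. That step shows that the placing of a methyl on this ring can matter, but it exchanges one position for another and adds no methyl. Going by the values given here, no measured step adds a second methyl, so only a modest rise in the number is expected, and perhaps none beyond the scatter. The estimate is a 1.7-fold higher number from compound 2 to compound 3 (0.23 log units; within the scatter). Compound 3 is expected at 4 nM, with an estimated range of 1.2 nM to 15 nM.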

Compound 3, half-maximal inhibitory concentration: 22.6 nM
For compound 3 the middle estimate is 5.7-fold (0.75 log units) below the measured one; the measured number lies above the stated range.
By their numbers in this assay, from the lowest: compound 2; then compounds 3 and 1 (each within the scatter of the next).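

In this assay the added methyl, meta to a large group and para to a methyl group, gives a 9.7-fold higher number from compound 2 to compound 3 (0.98 log units; beyond the scatter), so this ring carbon does not tolerate even one extra carbon without a clear loss, something the earlier change of methyl position could not show. The second comparison reads a 1.7-fold lower number from compound 1 to compound 3 (0.23 log units; within the scatter), so the 2,5-dimethylphenyl and 4-methylphenyl groups cannot be told apart here, even though compound 3 retains the methyl of compound 2. No measurement among the data shown accounts for this loss. The compounds shown leave open whether a fluorine atom or a methoxy group on the same carbon would raise the number as far. They also leave open whether a methyl at this place would have the same effect on a ring without the existing methyl.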